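The source may hold more compounds than are shown below. What is called first, only, known or untested is meant among the compounds shown, and "the series" means these compounds.

Compound 2 `CCCCCC(=O)Nc1ccc(S(=O)(=O)Oc2ccccc2I)cc1` gives 9600 nM in a functional assay on HT-1080 cells (Homo sapiens) for antiproliferative activity, read by sulforhodamine B assay, with a stated time of 48 h; on this read-out higher numbers stand for weaker inhibition and lower numbers for stronger inhibition. Its only companion, compound 1 `CCCCCC(=O)Nc1ccc(S(=O)(=O)Oc2ccccc2C(C)C)cc1`, gives 6300 nM, and the step of a 1.5-fold higher number from compound 1 to compound 2 (0.18 log units; within the scatter) concerns the aromatic substituent alone. Among the compounds with values here, compound 3 `CCCNC(=O)Nc1ccc(S(=O)(=O)Oc2ccccc2I)cc1` differs from compound 2 by propylamino in place of pentyl on a carbonyl carbon, a change on the carbonyl side that no measured pair touches. Within the data shown here, with no step bearing on it, the expected move a 1.5-fold higher number from compound 2 to compound 3 (0.16 log units; within the scatter) is set near none beyond the scatter, though with a wide band to reflect the missing evidence. Compound 3 is accordingly estimated at 14000 nM, between 3500 nM and 56000 nM.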

Compound 3, half-maximal inhibitory concentration: 700 nM
For compound 3 the middle estimate is 20-fold (1.30 log units) above the measured one; the measured number lies below the stated range.
By their numbers in this assay, from the lowest: compound 3; then compounds 1 and 2 (each within the scatter of the next).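

In this assay the carbonyl side proves far more sensitive than the aromatic substituent had been: propylamino in place of pentyl on a carbonyl carbon gives a 14-fold lower number from compound 2 to compound 3 (1.14 log units; beyond the scatter) and is the only step shown that lies beyond the scatter. No data shown explain why this change has so large an effect.

As far as these compounds go, it remains open whether the gain depends on the amino nitrogen itself or on its propyl chain, which a dimethylamino or pentylamino group would test. From the compounds shown here alone, it is also open whether the gain carries over when isopropyl replaces iodo.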